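The source may report more compounds than this note shows. Statements on the series, on what has been measured and on what is new or still open speak of the compounds shown alone.

Compound 1 `CC1(C)[C@H]2CC[C@]1(C)N(Cc1cn(-c3cccc(F)c3)nn1)C(=O)C2` gives 80 nM.
Compound 2 `CC1(C)[C@H]2CC[C@]1(C)N(Cc1cn(-c3ccccc3Br)nn1)C(=O)C2` gives 150 nM.
Compound 3 `CC1(C)[C@H]2CC[C@]1(C)N(Cc1cn(-c3ccc(F)cc3)nn1)C(=O)C2` gives 90 nM.

These numbers come from a functional assay on HepG2 cells (Homo sapiens) for inhibition, read by MTT assay, with a stated time of 24 h; a higher number here means a weaker inhibitor, a lower number a stronger inhibitor. Compound 1 gives the smallest of the three, yet a 1.1-fold higher number from compound 1 to compound 3 (0.05 log units; within the scatter) and a 1.9-fold higher number from compound 1 to compound 2 (0.27 log units; within the scatter) both stay within the scatter, so the three compounds cannot be separated on these data. Compound 4 `COc1ccccc1-n1cc(CN2C(=O)C[C@@H]3CC[C@@]2(C)C3(C)C)nn1` changes the group on the aromatic nitrogen of the shared core: 2-methoxyphenyl in place of 3-fluorophenyl on an aromatic nitrogen. The two steps that bear on it each swapped one substituted phenyl for another, and each stayed within the scatter, as did the exchange between compound 2 and compound 3. The expectation for compound 4 in this assay is therefore a step of about a 1.3-fold higher number from compound 1 to compound 4 (0.10 log units; within the scatter), which is no step beyond the scatter. The estimated value for compound 4 is 100 nM, with a range from 50 nM to 220 nM.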

Compound 4, half-maximal inhibitory concentration: 110 nM
The estimate for compound 4 lay 1.1-fold (0.04 log units) below the measured number; low and high end bracket the measured number.
By their numbers in this assay, from the lowest: compounds 1, 3, 4 and 2 (each within the scatter of the next).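

In this assay, within the data shown here, this position on the aromatic nitrogen also tolerates 2-methoxyphenyl, the first group here to carry a hydrogen-bond acceptor: a 1.4-fold higher number from compound 1 to compound 4 (0.14 log units; within the scatter) and a 1.2-fold higher number from compound 3 to compound 4 (0.09 log units; within the scatter) both stay within the scatter. Swapping bromo for methoxy on an aromatic carbon, a 1.4-fold lower number from compound 2 to compound 4 (0.13 log units; within the scatter), also stays within the scatter, so the acceptor brings no step that can be read. No measurement shown offers a reason for this. Still open, going by these compounds, is whether an amine or a carboxylic acid on the phenyl ring, or a longer chain in its place, would move the number beyond the scatter.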